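The source may report more compounds than this note shows. Statements on the series, on what has been measured and on what is new or still open speak of the compounds shown alone.

Compound 3 `COc1ccc(CNCc2c(OC)cc(Oc3cccc(Nc4ccccc4)c3)cc2OC)cc1` holds the lower of the two numbers given in a functional assay on HT-29 cells (Homo sapiens) for inhibition, read by MTT assay, with a stated time of 72 h; a higher number here means a weaker inhibitor, a lower number a stronger inhibitor: compound 3 gives 1890 nM. Compound 2 `COc1cc(Oc2cccc(Nc3ccccc3)c2)cc(OC)c1CNCc1ccc(C)cc1` gives 3880 nM, the gap being a 2.1-fold lower number from compound 2 to compound 3 (0.31 log units; beyond the scatter). Compound 1 `COc1cc(Oc2cccc(Nc3ccccc3)c2)cc(OC)c1CNC(C)C` reaches only a limit of the assay, > 20000 nM, as noted in the limit of > 20000 nM in this assay, at which 1 of the 3 values shown sits. The steps of an at least 5.1-fold lower number from compound 1 to compound 2 (0.71 log units; beyond the scatter) and an at least 10-fold lower number from compound 1 to compound 3 (1.02 log units; beyond the scatter) show that the benzyl groups on the amine nitrogen carry the measured inhibition. Compound 4 `COc1cc(Oc2cccc(Nc3ccccc3)c2)cc(OC)c1CCO` removes the amine altogether: hydroxymethyl in place of (4-methoxybenzyl)amino on a saturated chain carbon bound to an aromatic carbon. Among the measured compounds shown here, no measured step covers this change directly; the nearest guide is compound 1, whose value > 20000 nM is a limit. Compound 4 is therefore expected to shift by a 13-fold higher number from compound 3 to compound 4 (1.12 log units; beyond the scatter) toward weaker inhibition, most likely to the limit. The estimate for compound 4 is 25000 nM, within 5000 nM to 100000 nM.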

Compound 4, half-maximal inhibitory concentration: 13900 nM
For compound 4 the middle estimate is 1.8-fold (0.25 log units) above the measured one; the range from low to high includes it.
By their numbers in this assay, from the lowest: compound 3; then compound 2; then compound 4. At a limit, above all of these: compound 1.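

In this assay, the benzylamino groups outperform hydroxymethyl at this place, with a 7.4-fold higher number from compound 3 to compound 4 (0.87 log units; beyond the scatter) and a 3.6-fold higher number from compound 2 to compound 4 (0.55 log units; beyond the scatter), so both substituted benzylamino groups give lower numbers than the amine-free chain. Compound 4 still gives a number inside the assay's range, so a measurable value does not depend on an amine at this place. With hydroxymethyl in place of isopropylamino, the data give an at least 1.4-fold lower number from compound 1 to compound 4 (0.15 log units; that floor lies within the scatter). Compound 1 stands at a limit, so this step is only a floor: the limit of > 20000 nM in this assay, at which 1 of the 4 values shown sits.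

As far as these compounds go, whether the nitrogen or the aromatic ring of the benzylamino groups matters more stays open. A benzyl ether, a carboxylic acid or a longer chain at this place would help separate the two.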